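A Methoxyphenyl Swap Made Twice on Two Related Cores

The source may hold more compounds than are shown below. What is called first, only, known or untested is meant among the compounds shown, and "the series" means these compounds.

Of the compounds shown here, three from one series have been measured in a functional assay on MCF7 cells (Homo sapiens) for antiproliferative activity, read by sulforhodamine B assay, with a stated time of 72 h, tested at 10 uM; on this read-out lower numbers stand for a stronger effect and higher numbers for a weaker effect at the one concentration tested. Compound 1, `COC(=O)C1=C(N)Oc2c(OC)cc(Br)cc2C1CC(=O)c1ccc(Cl)cc1`, gives 80.3% in this assay. Compound 2, `COC(=O)C1=C(N)Oc2c(OC)cc(Br)cc2C1CC(=O)c1cccc(OC)c1`, differs from compound 1 in one place: 3-methoxyphenyl in place of 4-chlorophenyl on a carbonyl carbon. In this assay compound 2 gives 142%. That change made a step of a number 61.7 percentage points higher from compound 1 to compound 2 (beyond the scatter). Compound 3, `COc1cc(Br)cc2c1OC(N)=C(C#N)C2CC(=O)c1ccc(Cl)cc1`, keeps the side chain of compound 1 but carries a different core; the two cores differ as follows: cyano in place of methoxycarbonyl on a double-bonded ring carbon. In this assay compound 3 gives 49.6%, a step of a number 30.7 percentage points lower from compound 1 to compound 3 (beyond the scatter). Compound 3 thus gives the lowest number of the three, which on this read-out means the strongest effect at the one concentration tested.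

Compound 4, `COc1cccc(C(=O)CC2C(C#N)=C(N)Oc3c(OC)cc(Br)cc32)c1`, has not been measured. It stands to compound 3 as compound 2 stands to compound 1: 3-methoxyphenyl in place of 4-chlorophenyl on a carbonyl carbon. The place of the change is described in the same words in both pairs, so this is the same change, made for the second time in this set, now on the core that carries the cyano group rather than the methoxycarbonyl group. Within the data shown here, compound 4 is expected to move from compound 3 by a number 55.4 percentage points higher from compound 3 to compound 4 (beyond the scatter), an expectation that rests on the single step of a number 61.7 percentage points higher from compound 1 to compound 2 (beyond the scatter). Because the cores have already shown different numbers in a number 30.7 percentage points lower from compound 1 to compound 3 (beyond the scatter), the same change need not carry over exactly, so the range is kept wide. Compound 4 is estimated to give 105% in this assay, expected between 70% and 140%.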

Compound 4, a percentage reported as activity, at one concentration (the size of the read-out at that concentration, not a potency): 55.9%
Estimate against measurement, compound 4: 49.1 percentage points above; measured number below the stated range.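

In this assay, the swap of 4-chlorophenyl for 3-methoxyphenyl on the core that carries the cyano group gives a step of a number 6.3 percentage points higher from compound 3 to compound 4 (within the scatter), so the change did not carry over from the core with the methoxycarbonyl group at the size seen there: the same change on two cores in this assay, a number 61.7 percentage points higher (beyond the scatter) from compound 1 to compound 2 and a number 6.3 percentage points higher (within the scatter) from compound 3 to compound 4, 55.4 percentage points apart, beyond the scatter of two such steps

The same four compounds can be read the other way, with cyano in place of methoxycarbonyl while the 3-methoxyphenyl group stays, and that gives a step of a number 86.1 percentage points lower from compound 2 to compound 4 (beyond the scatter), much larger than the step for the same core change with 4-chlorophenyl: the same change on two cores in this assay, a number 30.7 percentage points lower (beyond the scatter) from compound 1 to compound 3 and a number 86.1 percentage points lower (beyond the scatter) from compound 2 to compound 4, 55.4 percentage points apart, beyond the scatter of two such steps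

So in these four compounds the effect of one change depends on what the rest of the molecule carries, and a step measured on one core is a poor guide to the other, but this rests on a single set of four compounds at one concentration and does not show why the two cores differ or how a third core would behave.

The compounds shown leave open how other groups on the carbonyl carbon, such as a plain phenyl ring or a longer alkyl chain, would behave on each core. They also leave open what a carboxylic acid or an amide would do in place of the cyano or methoxycarbonyl group on the double-bonded ring carbon.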